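The source may report more compounds than this note shows. Statements on the series, on what has been measured and on what is new or still open speak of the compounds shown alone.

In a functional assay on A549 cells (Homo sapiens) for antiproliferative activity, read by MTT assay, with a stated time of 48 h (a lower number here means a stronger inhibitor, a higher number a weaker inhibitor), compound 3 (`Cc1cccc(-c2nn(-c3ccccc3)cc2C(Nc2nc3ccccc3s2)c2c(O)ccc3ccccc23)c1`) gives 18500 nM. This lies within the scatter of compound 2 (`COc1cccc(-c2nn(-c3ccccc3)cc2C(Nc2nc3ccccc3s2)c2c(O)ccc3ccccc23)c1`), which gives 24800 nM. Compound 1 (`Cc1cc2nc(NC(c3cn(-c4ccccc4)nc3-c3ccc([N+](=O)[O-])cc3)c3c(O)ccc4ccccc34)sc2cc1C`) gives 41900 nM, a value beyond the scatter from that of compound 3.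

The next compound, compound 4 (`O=[N+]([O-])c1ccc(-c2nn(-c3ccccc3)cc2C(Nc2nc3ccccc3s2)c2c(O)ccc3ccccc23)cc1`), keeps the core of compound 3 and carries 4-nitrophenyl in place of 3-methylphenyl on an aromatic carbon of the five-membered aromatic ring with 2 nitrogen: 4-nitrophenyl in place of 3-methylphenyl on an aromatic carbon.

Two measurements bear on this change. Within the data shown here, the only measured step at this place is a 1.3-fold lower number from compound 2 to compound 3 (0.13 log units; within the scatter), so exchanging methyl for methoxy on the aryl group moved the number little. That step does not test 4-nitrophenyl, however. Among the measured compounds shown here, compound 1 is the only measured compound that carries 4-nitrophenyl, and at 41900 nM it hints at a somewhat higher number, although its core differs from that of compound 3 and no measured step isolates the group.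

A small rise is therefore expected, and the estimated 1.6-fold higher number from compound 3 to compound 4 (0.21 log units; within the scatter) would not clearly exceed the scatter. For compound 4 the expected value is 30000 nM, within an estimated range of 14000 nM to 60000 nM.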

Compound 4, half-maximal inhibitory concentration: 41300 nM
Compound 4: the middle estimate sits 1.4-fold (0.14 log units) below what was measured; the range from low to high includes it.
By their numbers in this assay, from the lowest: compounds 3, 2, 4 and 1 (each within the scatter of the next, the first and the last beyond it).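

The first direct test of 4-nitrophenyl at this place on the ring, read in this assay, gives a 2.2-fold higher number from compound 3 to compound 4 (0.35 log units; beyond the scatter) and so counts as a modest step, while a 1.7-fold higher number from compound 2 to compound 4 (0.22 log units; within the scatter) stays inside the scatter, which means that the group can be told apart from 3-methylphenyl but not from 3-methoxyphenyl. With 4-nitrophenyl held fixed, the exchange on the amine nitrogen gives a 1.0-fold lower number from compound 1 to compound 4 (0.01 log units; within the scatter) and shows that 1,3-benzothiazol-2-yl and 5,6-dimethyl-1,3-benzothiazol-2-yl cannot be told apart here, so the number of compound 1 no longer looks like an effect of its core. No measurement shown offers an explanation for the step at the aryl group.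

The compounds shown do not separate the change of substituent from its change of place on the phenyl ring, as 4-nitrophenyl is compared only with 3-methylphenyl and 3-methoxyphenyl. Going by these compounds, how an aryl group carrying an amine or a carboxylic acid would read at this place also remains open, as does whether the two methyl groups on the benzothiazole would matter as little alongside 3-methylphenyl.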